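A Methyl Ester Becomes a Free Acid

The source may hold more compounds than are shown below. What is called first, only, known or untested is meant among the compounds shown, and "the series" means these compounds.

In a functional assay on HeLa cells (Homo sapiens) for antiproliferative activity, read by MTT assay, with a stated time of 48 h (a lower number here means a stronger inhibitor, a higher number a weaker inhibitor), compound 1 `CC[C@@H](C)[C@H](NC(=O)c1ccc(Oc2nc3ccccc3nc2C)cc1)C(=O)OC` gives > 50000 nM, which is a limit of the assay and not a number.

Two relatives give numbers in this assay: compound 2 `COC(=O)[C@H](CC(C)C)NC(=O)c1ccc(Oc2nc3ccc(Cl)cc3nc2C)cc1` gives 37600 nM, and compound 3 `COC(=O)[C@H](CC(C)C)NC(=O)c1ccc(Oc2nc3cc(Cl)ccc3nc2C)cc1` gives 18600 nM. For the measured compounds named here, neither differs from compound 1 in one place alone, and no measured compound carries a carboxy group, so the data offer no direct guide.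

Compound 4 `CC[C@@H](C)[C@H](NC(=O)c1ccc(Oc2nc3ccccc3nc2C)cc1)C(=O)O` has hydrogen in place of methyl on an oxygen next to a carbonyl group, changing methoxycarbonyl to carboxy (hydrogen in place of methyl on an oxygen next to a carbonyl group).

In this assay, no step beyond the scatter is expected, and the estimated outcome is a step that the limit leaves unreadable from compound 1 to compound 4.

For compound 4 the expected value is 60000 nM, within an estimated range of 25000 nM to 150000 nM.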

Compound 4, half-maximal inhibitory concentration: 33200 nM
Compound 4: middle estimate off by 1.8-fold (0.26 log units), on the high side; the measured number falls inside the stated range.
By their numbers in this assay, from the lowest: compounds 3, 4 and 2 (each within the scatter of the next, the first and the last beyond it). At a limit, above all of these: compound 1.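

Compound 1 gives > 50000 nM as a limit of the assay and not a number. With carboxy in place of methoxycarbonyl, compound 4 gives a readable 33200 nM in this assay, the first value shown for a free acid in this series. For the compounds shown here, the step reads an at least 1.5-fold lower number from compound 1 to compound 4 (0.17 log units; that floor lies within the scatter) and shows only that this change does not leave the number at the limit, while its true size stays unread: the limit of > 50000 nM in this assay, at which 1 of the 4 values shown sits.

Going by these compounds, whether an ethyl ester or a primary amide at this place would shift the number remains open. So does the effect of the same change on the chlorine-bearing compound 2 and compound 3.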